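Swapping Methoxy for Hydroxy on Compound 2

The compounds below may be only part of what the source reports. "The series", "measured", "known", "first", "only" and "open" are said of these compounds alone.

Measured so far in a functional assay on MDA-MB-231 cells (Homo sapiens) for inhibition, read by MTT assay; a lower number here means a stronger inhibitor, a higher number a weaker inhibitor:
- compound 1 `CC(C)CCc1c(O)ccc2cc(-c3ccc(C(F)(F)F)cc3)c(=O)oc12`: > 50000 nM (a limit of the assay, not a number)
- compound 2 `COc1ccc2cc(-c3ccc(OC(F)(F)F)cc3)c(=O)oc2c1CCC(C)C`: 310 nM

For the measured compounds named here, with only two compounds measured, the picture is thin. Going by the values given here, compound 2 gives 310 nM, the only true number available, so it can be ranked against no other exact value. The other result is a limit, and that is all it is.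

Compound 3 `CC(C)CCc1c(O)ccc2cc(-c3ccc(OC(F)(F)F)cc3)c(=O)oc12` differs from compound 2 in one place hydrogen in place of methyl on an oxygen on an aromatic ring, which turns methoxy into hydroxy. Among the compounds with values here, no measured pair of compounds isolates this change, so any forecast rests on thin ground.

The one available hint comes from compound 1, which also carries the hydroxy group and whose result is the limit > 50000 nM. On that basis a clear loss of inhibition is expected in this assay, with the estimated step of a 39-fold higher number from compound 2 to compound 3 (1.59 log units; beyond the scatter) lying well beyond the scatter. Compound 3 is expected to come in near 12000 nM, within an estimated range of 2000 nM to 50000 nM.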

Compound 3, half-maximal inhibitory concentration: 7420 nM
For compound 3 the middle estimate is 1.6-fold (0.21 log units) above the measured one; low and high end bracket the measured number.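

In this assay, for the compounds shown here, the methoxy group of compound 2 clearly matters: hydrogen in place of methyl on that oxygen gives a 24-fold higher number from compound 2 to compound 3 (1.38 log units; beyond the scatter), the first direct reading of this change, yet hydroxy compound 3 still gives a measurable number, so this change weakens inhibition without abolishing it. With the hydroxy group held fixed, trifluoromethoxy in place of trifluoromethyl on an aromatic carbon gives an at least 6.7-fold lower number from compound 1 to compound 3 (0.82 log units; beyond the scatter), which shows that the hydroxy group alone does not set the poor result of compound 1. The result for compound 1 is a limit of the assay and not a number, so this step gives only a minimum size: the limit of > 50000 nM in this assay, at which 1 of the 3 values shown sits.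

As far as these compounds go, the change from methoxy to hydroxy is read here only once, with trifluoromethoxy on the far aromatic ring, so whether it has a similar size with trifluoromethyl remains open. Also open, from the compounds shown here alone, is how a larger ether such as ethoxy, or an amine in place of the hydroxy group, would compare with compound 2 and compound 3.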